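The source may hold more compounds than are shown below. What is called first, only, known or untested is meant among the compounds shown, and "the series" means these compounds.

Measured in a functional assay on A549 cells (Homo sapiens) for cytotoxicity, read by MTT assay, with a stated time of 72 h; a lower number here means a stronger inhibitor, a higher number a weaker inhibitor:
Compound 1 `CNC(=O)c1cc(Oc2ccc(C3=NNC(c4ccc(Cl)cc4Cl)C3)cc2)ccn1`: 6930 nM
Compound 2 `CNC(=O)c1cc(Oc2ccc(C3=NNC(c4cccc(Br)c4)C3)cc2)ccn1`: 2840 nM

Compound 2 holds the lower of the two numbers, at 2840 nM. Compound 3 `CNC(=O)c1cc(Oc2ccc(C3=NNC(c4ccc(C#N)cc4)C3)cc2)ccn1` has 4-cyanophenyl in place of 3-bromophenyl on a saturated ring carbon. Within the data shown here, the only measured step at that carbon, a 2.4-fold lower number from compound 1 to compound 2 (0.39 log units; beyond the scatter), was modest and involved different groups, so it offers only a rough guide to size. A step of similar modest size is expected in this assay, with the direction uncertain and a slight lean towards a higher number. The expected change is an estimated 1.3-fold higher number from compound 2 to compound 3 (0.13 log units; within the scatter). Compound 3 is estimated at 3800 nM, with an expected range of 1400 nM to 10000 nM.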

Compound 3, half-maximal inhibitory concentration: 17400 nM
Estimate against measurement, compound 3: 4.6-fold (0.66 log units) below, and the stated range ends below it.
By their numbers in this assay, from the lowest: compound 2; then compound 1; then compound 3.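

In this assay, among these compounds, the group on this saturated ring carbon proves able to move the number further than the first pair showed: 4-cyanophenyl gives the largest step so far (a 6.1-fold higher number from compound 2 to compound 3 (0.79 log units; beyond the scatter)). It also stands apart from 2,4-dichlorophenyl (a 2.5-fold higher number from compound 1 to compound 3 (0.40 log units; beyond the scatter)), so both halogen-bearing phenyl groups shown give lower numbers than the nitrile-bearing one. No supporting data explain this difference.

Since 3-bromophenyl and 4-cyanophenyl differ in both substituent and its place on the ring, the compounds shown do not separate these two changes. Going by these compounds, how an amine or a carboxylic acid on this phenyl ring would compare also remains open.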